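Fluorine on the aryl ring of a thiazole amide scaffold

This account rests on a few compounds, and the source may have more. Where it says the series, first, only, none or still open, it means among the compounds named here.

Of the compounds shown here, three sharing a thiazole-based core have been tested for their ability to slow the movement of breast cancer cells. In a functional assay on MDA-MB-231 cells (Homo sapiens), read by microscopy and transwell migration, with a stated time of 24 h (on this read-out lower numbers stand for stronger inhibition and higher numbers for weaker inhibition), compound 1 (`Cc1sc(NC(=O)c2ccccc2)nc1-c1ccccc1`) reports only a limit of the assay, > 25000 nM, which is the limit of > 25000 nM in this assay, at which 1 of the 3 values shown sits. Compound 2 (`Cc1sc(NC(=O)c2ccccc2)nc1-c1ccc(F)cc1`) differs by fluoro in place of hydrogen on an aromatic carbon and gives 9100 nM, so the measured step is an at least 2.7-fold lower number from compound 1 to compound 2 (0.43 log units; beyond the scatter). Compound 3 (`Cc1s/c(=N\C(=O)c2ccccc2)n(C)c1-c1ccccc1`) carries a different core whose difference from compound 1 is not broken down here, and in this assay compound 3 gives 197 nM, the lowest number among the measured compounds. Compound 4 (`Cc1s/c(=N\C(=O)c2ccccc2)n(C)c1-c1ccc(F)cc1`) is not yet measured; it differs from compound 3 by fluoro in place of hydrogen on an aromatic carbon, the same change that separates compound 1 from compound 2. The expected step of a 2.0-fold lower number from compound 3 to compound 4 (0.29 log units; within the scatter) rests on the step of an at least 2.7-fold lower number from compound 1 to compound 2 (0.43 log units; beyond the scatter), allowing that the first step is only a limit. Compound 4 is therefore expected to land near 100 nM, with the estimate running from 30 nM to 400 nM.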

Compound 4, half-maximal inhibitory concentration: 847 nM
For compound 4 the middle estimate is 8.5-fold (0.93 log units) below the measured one, and the stated range ends below it.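

On the core of compound 3, going from phenyl to 4-fluorophenyl gives a 4.3-fold higher number from compound 3 to compound 4 (0.63 log units; beyond the scatter) in this assay, so the change that lowered the number on the core of compound 1 raises it here. The result on one core therefore did not carry over to the other, and the two steps clearly disagree: the same change on two cores in this assay, an at least 2.7-fold lower number (0.43 log units; beyond the scatter) from compound 1 to compound 2 and a 4.3-fold higher number (0.63 log units; beyond the scatter) from compound 3 to compound 4, at least 11-fold (1.07 log units) apart, beyond the scatter of two such steps

With only two cores compared, this does not show why they respond differently or how a third core would respond, and the value of compound 1 is a limit rather than a number: the limit of > 25000 nM in this assay, at which 1 of the 4 values shown sits.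

The compounds shown leave open how either core would respond to other groups at the same place on the ring, such as chloro, methoxy or a carboxylic acid. They also leave open whether the same opposite steps would appear in a different read-out or in another cell line.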